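The source may report more compounds than this note shows. Statements on the series, on what has been measured and on what is new or still open speak of the compounds shown alone.

Of the compounds shown here, two have been measured so far. Compound 1 `Cc1nn(C)c2nc(NNC(=O)Nc3cc(Cl)nc(Cl)c3)cc(C3CC3)c12` gives 3650 nM in an assay on isolated protein for binding affinity to sphingosine 1-phosphate receptor 2 (Homo sapiens), read by surface plasmon resonance (a lower number here means tighter binding, a higher number weaker binding), and compound 2 `COc1ccc(-c2cc(NNC(=O)Nc3cc(Cl)nc(OC(C)C)c3)nc3c2cnn3C)cc1` gives 2320 nM; of the two numbers that of compound 1 is the higher, yet the gap to compound 2 lies within the scatter, so the two cannot be ordered. The next compound, compound 3 `CCCc1cc(NNC(=O)Nc2cc(Cl)nc(Cl)c2)nc2c1c(C)nn2C`, differs from compound 1 in one place: propyl in place of cyclopropyl on an aromatic carbon. Among the measured compounds shown here, no measured pair shows what this exchange does, so the step is expected to stay within the scatter, with no direction beyond it. The estimate a 1.0-fold lower number from compound 1 to compound 3 (0.02 log units; within the scatter) puts compound 3 at 3500 nM, within a range from 1500 nM to 8000 nM.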

Compound 3, dissociation constant: 2360 nM
Estimate against measurement, compound 3: 1.5-fold (0.17 log units) above; low and high end bracket the measured number.
By their numbers in this assay, from the lowest: compounds 2, 3 and 1 (each within the scatter of the next).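

In this assay, the exchange of cyclopropyl for propyl on this aromatic carbon, opposite the ring nitrogen, gives a 1.5-fold lower number from compound 1 to compound 3 (0.19 log units; within the scatter), the first step read at this position. Opening the three-membered ring, with the count of heavy atoms unchanged, thus leaves the two compounds indistinguishable in this measurement. Nothing at hand bears on why this is so. As far as these compounds go, whether a longer chain, such as hexyl, or an amine at this position would give a step beyond the scatter stays open. So does whether the same exchange would behave alike on a different core.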